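This account rests on a few compounds, and the source may have more. Where it says the series, first, only, none or still open, it means among the compounds named here.

Values in a functional assay on A2780 cells (Homo sapiens) for antiproliferative activity, read by MTT assay, with a stated time of 48 h; a lower number here means a stronger inhibitor, a higher number a weaker inhibitor:

- compound 1 `COc1ccc(C(=O)c2ccc3c(c2)C=CC(C)(C)O3)c(NC(=O)CBr)c1`: 1870 nM
- compound 2 `COc1ccc(C(=O)c2ccc3c(c2)C=CC(C)(C)O3)c(NC(=O)CO)c1`: 130 nM

Among the compounds with values here, of the two measured compounds, compound 2 has the lower number in this assay, at 130 nM, while its only neighbour, compound 1, gives 1870 nM. The next compound, compound 3 `COc1ccc(C(=O)c2ccc3c(c2)C=CC(C)(C)O3)c(NC(=O)CN)c1`, keeps the shared core and changes a single group: amino in place of hydroxy on a saturated chain carbon bound to a carbonyl carbon. Within the data shown here, one measured step bears on this place, where hydroxy replaced bromo: a 14-fold lower number from compound 1 to compound 2 (1.16 log units; beyond the scatter). That step is large and beyond the scatter, so the number in this assay can respond strongly to the group carried here. Among the measured compounds shown here, still, no compound with amino has been measured, and this single step gives no direction for the new exchange. The expectation is therefore no clear change beyond the scatter, with a wider shift either way remaining possible. The expected step is a 1.1-fold lower number from compound 2 to compound 3 (0.03 log units; within the scatter). For compound 3 the estimated value is 120 nM, within an expected range of 30 nM to 500 nM.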

Compound 3, half-maximal inhibitory concentration: 590 nM
Beside the measured number, compound 3's estimate is 4.9-fold (0.69 log units) below it, outside the stated range (above it).
By their numbers in this assay, from the lowest: compound 2; then compound 3; then compound 1.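

In this assay, this place on a saturated chain carbon bound to a carbonyl carbon now separates three groups rather than two: amino in place of hydroxy gives a 4.5-fold higher number from compound 2 to compound 3 (0.66 log units; beyond the scatter), while amino in place of bromo gives a 3.2-fold lower number from compound 1 to compound 3 (0.50 log units; beyond the scatter). Amino therefore takes the middle place, with the order from the lowest number running hydroxy, amino, bromo, and every step among these three compounds lies beyond the scatter; hydroxy and amino match in heavy atom count, ring count, hydrogen-bond donors and acceptors, and net charge, yet they do not give the same number. Nothing at hand accounts for this order.

The compounds shown leave open how a methoxy group, a dimethylamino group or a carboxylic acid at this place would fit into that order, and whether a longer chain ending in hydroxy or amino would keep it. On these data alone, all three compounds also share the rest of the core, so it remains open whether the same order holds when another part of the structure changes.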